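This account rests on a few compounds, and the source may have more. Where it says the series, first, only, none or still open, it means among the compounds named here.

Measured in a functional assay, with a stated time of 30 min; a higher number here means a weaker inhibitor, a lower number a stronger inhibitor:
compound 1 `Cc1cccc(/C=N/c2ccc(OCc3ccccc3)cc2)c1O` gives > 200000 nM.
compound 2 `O=[N+]([O-])c1ccc(O)c(/C=N/c2ccc(OCc3ccccc3)cc2)c1` gives > 200000 nM.

The value for compound 1 is a limit of the assay, not a number. The value for compound 2 is likewise a limit of the assay and not a number. Compound 2 thus stands at the limit of > 200000 nM in this assay, at which 2 of the 2 values shown sit. No ordering of the two measured compounds can be read from this; both show only that no inhibition was reached within the tested range.

The step to compound 3 `Oc1ccc(Br)cc1/C=N/c1ccc(OCc2ccccc2)cc1` is bromo in place of nitro on an aromatic carbon, in words bromo in place of nitro on an aromatic carbon. Among the measured compounds shown here, no step between measured compounds is available for comparison; the expectation rests solely on where compound 2 stands. Compound 3 is expected to remain at or close to the limit, with a step of a number no higher from compound 2 to compound 3 (the limit leaves the size open) that is not expected to carry it clearly into the measurable range. The estimate for compound 3 in this assay is 200000 nM, with a range from 50000 nM to 1000000 nM, and the most likely outcome is that this assay again reports only a limit.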

Compound 3, half-maximal inhibitory concentration: > 200000 nM
Compound 3 ended at the assay's limit; the forecaster's own chance of this, stated with the estimate: 80%; the middle value sits exactly at the limit.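

No step can be read between compound 3 and either compound 1 or compound 2, as all three stand at the same limit of the assay: the limit of > 200000 nM in this assay, at which 3 of the 3 values shown sit.

The compounds shown leave open how these three rank against one another and whether any change on the shared core brings inhibition into the measurable range.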